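Swapping methylsulfanyl for a larger polar ring

The source may report more compounds than this note shows. Statements on the series, on what has been measured and on what is new or still open speak of the compounds shown alone.

Within the data shown here, compound 2 `CSc1cnc(C(=O)CCCCCCc2ccccc2)o1` is the only compound here with a definite number: in an assay (Rattus norvegicus) for inhibition of Fatty-acid amide hydrolase 1 (Homo sapiens) (on this read-out lower numbers stand for stronger inhibition and higher numbers for weaker inhibition), compound 2 gives 25 nM. Compound 1 `O=C(CCCCCCc1ccccc1)c1ncc(-c2ncccc2C(=O)O)o1` carries 3-carboxypyridin-2-yl on the same aromatic carbon in place of methylsulfanyl. In this assay compound 1 gives only a limit, > 50 nM. The step of an at least 2.0-fold lower number from compound 1 to compound 2 (0.30 log units; that floor lies within the scatter) thus shows the smaller group at the lower, stronger number, by a floor that lies within the scatter. Compound 3 `O=C(CCCCCCc1ccccc1)c1ncc(-c2cc(=O)[nH]c(=O)[nH]2)o1` differs from compound 2 by a group of 8 heavy atoms (4 carbon, 2 nitrogen, 2 oxygen; one six-membered aromatic ring with 2 hetero atoms) in place of a group of 2 heavy atoms (1 carbon, 1 sulfur; no ring), on an aromatic carbon. Among the measured compounds shown here, this change resembles the one from compound 2 back to compound 1, a small group giving way to a ring bearing polar groups, and the one measured step that bears on it, an at least 2.0-fold lower number from compound 1 to compound 2 (0.30 log units; that floor lies within the scatter), points toward a weaker number, while the limit of > 50 nM in this assay, at which 1 of the 2 values shown sits, leaves its full size open. Compound 3 is therefore expected to sit weaker than compound 2 by a 4.8-fold higher number from compound 2 to compound 3 (0.68 log units; beyond the scatter), with an estimated value of 120 nM in a range from 25 nM to 600 nM.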

Compound 3, inhibition constant: 12 nM
Beside the measured number, compound 3's estimate is 10-fold (1.00 log units) above it; measured number outside the range, below it.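

At this aromatic carbon, next to the ring oxygen, a large ring does not cost inhibition in this assay, since the change from methylsulfanyl gives a 2.1-fold lower number from compound 2 to compound 3 (0.32 log units; beyond the scatter) and stays on the stronger side. So the size of the entering group does not by itself set the number here, and the earlier step had hinted otherwise only by a floor within the scatter. Two rings of similar size also part clearly, with an at least 4.1-fold lower number from compound 1 to compound 3 (0.61 log units; beyond the scatter) as the step, although compound 1 gives only a limit (> 50 nM) and not a number.

What the entering ring contributes stays unresolved, and a plain phenyl ring or a simple amine on this carbon would help separate the ring itself from its other atoms. The distance from compound 1 to the other two also stays open because its value is not a number: the limit of > 50 nM in this assay, at which 1 of the 3 values shown sits.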